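Methoxy on the phenylsulfonyl: compound 1 to compound 4

The source may report more compounds than this note shows. Statements on the series, on what has been measured and on what is new or still open speak of the compounds shown alone.

In a functional assay on A549 cells (Homo sapiens) for cytotoxicity, read by MTT assay, with a stated time of 72 h (on this read-out lower numbers stand for stronger inhibition and higher numbers for weaker inhibition), compound 1 `COc1cc(Nc2nc3ccccc3nc2S(=O)(=O)c2ccccc2)cc(OC)c1OC` gives 9660 nM, the lowest of the two numbers shown. Compound 2 `Cc1ccc(S(=O)(=O)c2nc3ccccc3nc2Nc2ccccc2)cc1` gives 12500 nM, which lies within the scatter of compound 1. Compound 3 `COc1ccc(Nc2nc3ccccc3nc2S(=O)(=O)c2ccc(C)cc2)cc1` reaches only the assay limit, > 50000 nM. Among the compounds with values here, the single measured step of this kind, an at least 4.0-fold higher number from compound 2 to compound 3 (0.60 log units; beyond the scatter), gave a clearly weaker number. Compound 4 `COc1ccc(S(=O)(=O)c2nc3ccccc3nc2Nc2cc(OC)c(OC)c(OC)c2)cc1` differs from compound 1 by methoxy in place of hydrogen on an aromatic carbon; the methoxy enters on the phenylsulfonyl rather than on the anilino ring, so the measured step bears on it only loosely, and a modest weakening is expected. Compound 4 is expected at 20000 nM, with a range from 7000 nM to 50000 nM. This corresponds to an expected step of a 2.1-fold higher number from compound 1 to compound 4 (0.32 log units; beyond the scatter).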

Compound 4, half-maximal inhibitory concentration: 5170 nM
For compound 4 the middle estimate is 3.9-fold (0.59 log units) above the measured one; the measured number lies below the stated range.
By their numbers in this assay, from the lowest: compounds 4, 1 and 2 (each within the scatter of the next, the first and the last beyond it). At a limit, above all of these: compound 3.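

On the core of compound 1 in this assay, phenylsulfonyl to (4-methoxyphenyl)sulfonyl gives a 1.9-fold lower number from compound 1 to compound 4 (0.27 log units; within the scatter), so methoxy at this position, para to a large group, leaves the number within the scatter. The earlier step therefore does not carry over as a general effect of methoxy, and the outcome depends on where the change is made: the same change on two cores in this assay, an at least 4.0-fold higher number (0.60 log units; beyond the scatter) from compound 2 to compound 3 and a 1.9-fold lower number (0.27 log units; within the scatter) from compound 1 to compound 4, at least 7.4-fold (0.87 log units) apart, beyond the scatter of two such steps

Open, on these data alone, is how an amine, a carboxylic acid or a longer alkoxy chain would read at this position. Also open, as far as these compounds go, is whether the result holds beyond this single cell line.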